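Adding a Second Methyl to the Amide-Side Ring

The compounds below may be only part of what the source reports. "The series", "measured", "known", "first", "only" and "open" are said of these compounds alone.

Measured so far:
compound 1, `CCNC(=O)c1cc(-c2ccc(F)cc2F)ccc1OC(C)=O`, gives 23.9%
compound 2, `CC(=O)Oc1ccc(-c2ccc(F)cc2F)cc1C(=O)Nc1ccc(C)cc1`, gives 31%
compound 3, `CC(=O)Oc1ccc(-c2ccc(F)cc2F)cc1C(=O)Nc1cc(C)ccc1C`, not yet measured

Of the compounds shown here, two with a shared core have been tested in a functional assay on the whole organism (strain Kunming) for inhibition, with Mus musculus as the target, in the writhing test, at a dose of 40 mg/kg by the oral route; a lower number here means less inhibition, a higher number more inhibition at the dose given (going by the name of the read-out). Compound 2 gives the higher of the two numbers, but its step to compound 1, a number 7.1 percentage points higher from compound 1 to compound 2 (within the scatter), is within the scatter, so the two cannot be told apart on these data. That one step swaps a small chain for an aromatic ring on the amide-type nitrogen.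

Compound 3 keeps the core of compound 2 and changes only the ring on that nitrogen: 2,5-dimethylphenyl in place of 4-methylphenyl on an amide-type nitrogen. For the measured compounds named here, no measured step moves a methyl around an aromatic ring or adds a second one, so the only guide is that a much larger change at the same place, from compound 1 to compound 2, stayed within the scatter. On that basis the step of a number 1 percentage points lower from compound 2 to compound 3 (within the scatter) is expected to stay within the scatter as well. Compound 3 is therefore estimated at 30% in this assay, with a range from 15% to 45%.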

Compound 3, a percentage reported as inhibition, in the whole organism at one dose (the size of the read-out at that dose, not a potency): 13.2%
For compound 3 the middle estimate is 16.8 percentage points above the measured one; measured number outside the range, below it.
By their numbers in this assay, from the lowest: compound 3; then compounds 1 and 2 (each within the scatter of the next).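

In this assay, for the compounds shown here, this position on the amide-type nitrogen proves sensitive to a change far smaller than swapping a chain for a ring: 2,5-dimethylphenyl in place of 4-methylphenyl gives a number 17.8 percentage points lower from compound 2 to compound 3 (beyond the scatter) and is the first step to clear the scatter. Placing 2,5-dimethylphenyl where the ethyl stood gives a number 10.7 percentage points lower from compound 1 to compound 3 (beyond the scatter) in the same test, so compound 3 now has the lowest number of the three, and an aromatic ring on this nitrogen does not fix the read-out at one level, since compound 2 and compound 3 both carry one and still differ. No measurement shown here accounts for this drop.

The step from compound 2 to compound 3 both adds a methyl and changes where the methyls sit on the ring, and the compounds shown cannot separate those two changes. Also open is how an unsubstituted phenyl ring or a longer chain such as butyl would behave on this nitrogen, as neither appears among these compounds.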